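Methoxy for fluoro on the aryl group of compound 3

This account rests on a few compounds, and the source may have more. Where it says the series, first, only, none or still open, it means among the compounds named here.

Compound 3 `Fc1ccc(NC(=S)N/N=C/c2ccc3ccccc3n2)cc1` gives 32300 nM in a functional assay on SGC-7901 cells (Homo sapiens) for antiproliferative activity, read by sulforhodamine B assay, with a stated time of 72 h; on this read-out higher numbers stand for weaker inhibition and lower numbers for stronger inhibition. Compound 1 `S=C(N/N=C/c1ccc2ccccc2n1)Nc1cccc(Cl)c1` gives 61300 nM and compound 2 `S=C(NCc1ccccc1)N/N=C/c1ccc2ccccc2n1` gives 53700 nM. The steps of a 1.9-fold lower number from compound 1 to compound 3 (0.28 log units; within the scatter), a 1.7-fold lower number from compound 2 to compound 3 (0.22 log units; within the scatter) and a 1.1-fold lower number from compound 1 to compound 2 (0.06 log units; within the scatter) all stay within the scatter, so compound 3 is not set apart from either companion. Compound 4 `COc1ccc(NC(=S)N/N=C/c2ccc3ccccc3n2)cc1` carries methoxy in place of fluoro on an aromatic carbon. Among the compounds with values here, no measured step swaps a substituent on the same aryl group; the nearest guidance is that replacing the whole group on the amide-type nitrogen, in a 1.9-fold lower number from compound 1 to compound 3 (0.28 log units; within the scatter) and a 1.7-fold lower number from compound 2 to compound 3 (0.22 log units; within the scatter), gave nothing beyond the scatter. The step of a 1.0-fold lower number from compound 3 to compound 4 (0.00 log units; within the scatter) is therefore expected to remain within the scatter as well. Compound 4 is estimated at 32000 nM, with a range from 12000 nM to 85000 nM.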

Compound 4, half-maximal inhibitory concentration: 89600 nM
Compound 4: the middle estimate sits 2.8-fold (0.45 log units) below what was measured; measured number above the stated range.
By their numbers in this assay, from the lowest: compounds 3, 2, 1 and 4 (each within the scatter of the next, the first and the last beyond it).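

Within the data shown here, the step of a 2.8-fold higher number from compound 3 to compound 4 (0.44 log units; beyond the scatter) is the first to pass the scatter, so a swap of one substituent on an aromatic carbon, para to a large group, separates two compounds where no earlier replacement of the whole group on the amide-type nitrogen did. The steps of a 1.7-fold higher number from compound 2 to compound 4 (0.22 log units; within the scatter) and a 1.5-fold higher number from compound 1 to compound 4 (0.16 log units; within the scatter) stay within the scatter, so compound 4 is set apart from compound 3 alone. No measurement shown bears on why this swap counts at this position.

From the compounds shown here alone, whether the step belongs to the methoxy group itself or to the loss of fluoro stays open, as does how an amine, a hydroxyl or a longer chain such as ethoxy would read at this place.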